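From Methyl to Methylsulfonyl on the Ring Nitrogen

The source may report more compounds than this note shows. Statements on the series, on what has been measured and on what is new or still open speak of the compounds shown alone.

In an assay on COS-7 cells for inhibition of patatin-like phospholipase domain-containing protein 2 (Mus musculus), tested at 200 uM (a higher number here means more inhibition at the concentration tested (going by the name of the read-out), a lower number less inhibition), compound 1 `CCOC(=O)c1cccc(-c2ccc(OCC)cc2)n1` gives 79%, compound 2 `CCOC(=O)c1cccc(-c2ccc(CN(C)C)o2)c1` gives 53%, and compound 3 `CCOC(=O)c1cccc(-c2ccc(CN3CCN(C)CC3)o2)c1` gives 67%. Compound 3 thus stands second of the three, below compound 1 and above compound 2, both gaps lying beyond the usual scatter. Within the data shown here, the only measured step, a number 14 percentage points higher from compound 2 to compound 3 (beyond the scatter), exchanged the amine on the saturated chain carbon. Compound 4 `CCOC(=O)c1cccc(-c2ccc(CN3CCN(S(C)(=O)=O)CC3)o2)c1` alters compound 3 at a different place: methylsulfonyl in place of methyl on an amine nitrogen in a ring. Among the measured compounds shown here, no measured pair shows a change of this kind, so the one known step bears on it only loosely. A move that stays near the scatter is expected, a number 3 percentage points lower from compound 3 to compound 4 (within the scatter). Compound 4 is therefore estimated at 64%, with a range from 48% to 80%.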

Compound 4, a percentage reported as inhibition, at one concentration (the size of the read-out at that concentration, not a potency): 66%
Compound 4: middle estimate off by 2 percentage points, on the low side; measured number inside the range.
By their numbers in this assay, from the lowest: compound 2; then compounds 4 and 3 (each within the scatter of the next); then compound 1.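

In this assay, the exchange of methyl for methylsulfonyl on the amine nitrogen in the ring gives a number 1 percentage points lower from compound 3 to compound 4 (within the scatter) and so leaves the reading within the scatter. This position therefore accepts four heavy atoms in place of one, and two hydrogen-bond acceptors in place of none, with no reading outside the scatter. The data offer no measurement that would explain this result. On these data alone, whether an acetyl group or a bare hydrogen on this nitrogen would also stay within the scatter of compound 3 remains open.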